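The compounds below may be only part of what the source reports. "The series", "measured", "known", "first", "only" and "open" are said of these compounds alone.

Compound 2, `Nc1ncnn2c([C@@H]3O[C@H](CO)[C@@H](O)[C@H]3O)cc(-c3ccc(Cl)cc3)c12`, gives 47800 nM in a functional assay on K562 cells (Homo sapiens) for antiproliferative activity, with a stated time of 72 h; a lower number here means a stronger inhibitor, a higher number a weaker inhibitor. Among the measured compounds shown here, of the two values recorded in this assay, that is the only one that is a number. Compound 1, `Nc1ncnn2c([C@@H]3O[C@H](CO)[C@@H](O)[C@H]3O)cc(C#Cc3cccs3)c12`, yields in this assay > 100000 nM, which is a limit of the assay rather than a number. For the measured compounds named here, the single measured step, an at least 2.0-fold lower number from compound 1 to compound 2 (0.32 log units; beyond the scatter), arises from 4-chlorophenyl in place of 2-(thiophen-2-yl)ethynyl on an aromatic carbon, and its size is known only as a bound because the value it starts from is a limit (the limit of > 100000 nM in this assay, at which 1 of the 2 values shown sits).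

Compound 3, `Nc1ncnn2c([C@@H]3O[C@H](CO)[C@@H](O)[C@H]3O)cc(-c3ccc(F)cc3F)c12`, has not yet been measured in this assay. It differs from compound 2 by 2,4-difluorophenyl in place of 4-chlorophenyl on an aromatic carbon. Going by the values given here, the measured step swapped an alkynyl-linked thiophene for a halophenyl; no measured step exchanges one halogen for another on a six-membered aromatic ring of carbon only, so that step bears on compound 3 only loosely. The expectation is therefore a step within the scatter, leaning slightly toward a weaker inhibitor, a 1.3-fold higher number from compound 2 to compound 3 (0.10 log units; within the scatter). Compound 3 is estimated at 60000 nM, in the range 20000 nM to 150000 nM.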

Compound 3, half-maximal inhibitory concentration: 69700 nM
Compound 3: middle estimate off by 1.2-fold (0.07 log units), on the low side, within the range that was stated.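

In this assay, the exchange of one halogenated phenyl for another on this aromatic carbon gives a 1.5-fold higher number from compound 2 to compound 3 (0.16 log units; within the scatter), so 4-chlorophenyl and 2,4-difluorophenyl cannot be told apart here, a comparison that the earlier pair of compounds did not offer. Replacing 2-(thiophen-2-yl)ethynyl with 2,4-difluorophenyl gives an at least 1.4-fold lower number from compound 1 to compound 3 (0.15 log units; that floor lies within the scatter), so this second halogenated phenyl does not establish a difference from the alkynyl group, whereas the earlier step with 4-chlorophenyl, an at least 2.0-fold lower number from compound 1 to compound 2 (0.32 log units; beyond the scatter), did. That reading stays open-ended, as compound 1 carries a limit and the step is known only as a bound because it starts from that limit: the limit of > 100000 nM in this assay, at which 1 of the 3 values shown sits.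

The compounds shown leave open whether a group without halogen on this aromatic carbon, such as an unsubstituted phenyl, an amine, a carboxylic acid or a longer chain, would move the number beyond the scatter from that of compound 2. They also cannot separate the change of halogen from the change in the number and placement of halogens, since compound 3 differs from compound 2 in all of these at once, and a 4-fluorophenyl group would be needed to pull them apart.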